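A few compounds are considered here, and "the series" means these few. Any claim that something is new, unique, unknown or untested is made for them only; others in the source may bear on it.

In a functional assay on PC-3 cells (Homo sapiens) for antiproliferative activity, read by MTT assay, with a stated time of 72 h (on this read-out higher numbers stand for weaker inhibition and lower numbers for stronger inhibition), compound 1 `O=C(N/N=C/c1ccccc1)Nc1ccc(Oc2ccnc3[nH]ccc23)cc1` gives 10200 nM and compound 2 `O=C(N/N=C/c1ccc(O)cc1)Nc1ccc(Oc2ccnc3[nH]ccc23)cc1` gives 4920 nM. Among the measured compounds shown here, the one measured step between them is a 2.1-fold lower number from compound 1 to compound 2 (0.32 log units; beyond the scatter), where hydroxy takes the place of hydrogen on an aromatic carbon. Compound 3 `O=C(N/N=C/c1ccc(O)cc1Br)Nc1ccc(Oc2ccnc3[nH]ccc23)cc1` stands apart from this pair. It is reported as "not active" (no number reported), with no single number, so it offers no numerical starting point. Compound 4 `CN(C)CCCn1cccc1/C=N/NC(=O)Nc1ccc(Oc2ccnc3[nH]ccc23)cc1` has not yet been measured. The change from compound 3 is 1-(3-(dimethylamino)propyl)-1H-pyrrol-2-yl in place of 2-bromo-4-hydroxyphenyl on a carbon with a double bond to nitrogen. In words, 1-(3-(dimethylamino)propyl)-1H-pyrrol-2-yl comes in place of 2-bromo-4-hydroxyphenyl on a carbon with a double bond to nitrogen.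

The measured step bears on this only loosely. For the measured compounds named here, it is modest and concerns a single hydroxy, whereas here the whole group changes, and no measured compound carries the entering group. No size can therefore be put on the step from compound 3 in this assay. The expected direction is from no reported number to a measurable one, in the general region of compound 2 at 4920 nM, with a real chance of another result without a number. Compound 4 is estimated at 4000 nM, with an expected range of 600 nM to 20000 nM.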

Compound 4, half-maximal inhibitory concentration: 5150 nM
The estimate for compound 4 lay 1.3-fold (0.11 log units) below the measured number, within the range that was stated.
By their numbers in this assay, from the lowest: compounds 2, 4 and 1 (each within the scatter of the next, the first and the last beyond it).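

In this assay the place on a carbon with a double bond to nitrogen accepts 1-(3-(dimethylamino)propyl)-1H-pyrrol-2-yl, a five-membered aromatic ring carrying a chain, in place of 4-hydroxyphenyl, with a 1.0-fold higher number from compound 2 to compound 4 (0.02 log units; within the scatter) and thus no readable difference between the two groups. The phenyl comparison also stays within the scatter, at a 2.0-fold lower number from compound 1 to compound 4 (0.30 log units; within the scatter), so a measurable number at this place in this assay does not depend on a six-membered aromatic ring of carbon only or on a hydroxy group. The step from compound 3 cannot be read, as compound 3 has no number. Nothing measured here accounts for these results.

The compounds shown leave open which part of the entering group matters, the 1H-pyrrol-2-yl ring, the propyl chain or the dimethylamino group. A plain 1H-pyrrol-2-yl without the chain, a longer chain such as butyl, or a carboxylic acid in place of the dimethylamino group would each separate these parts in this series.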